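From piperidin-1-yl to 2,6-dimethylmorpholin-4-yl on a weak compound

The compounds below may be only part of what the source reports. "The series", "measured", "known", "first", "only" and "open" are said of these compounds alone.

So far, two compounds have been tested in a functional assay on DU-145 cells (Homo sapiens) for inhibition, read by MTT assay, with a stated time of 48 h; on this read-out lower numbers stand for stronger inhibition and higher numbers for weaker inhibition. Compound 1 (`CCn1c(/C=C2\SC(=O)N(CC(=O)N3CC(C)OC(C)C3)C2=O)nc2ccccc21`) gives > 50000 nM, which is a limit of the assay and not a number. Among the measured compounds shown here, compound 2 (`CC(C)n1c(/C=C2\SC(=O)N(CC(=O)N3CCCCC3)C2=O)nc2ccccc21`) gives 42200 nM, the only exact number available, so it has no other exact value to be ranked against. Since lower numbers mean stronger inhibition, this is a weak result.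

Compound 3 (`CC1CN(C(=O)CN2C(=O)S/C(=C\c3nc4ccccc4n3C(C)C)C2=O)CC(C)O1`) has not been measured yet. It differs from compound 2 in one place: 2,6-dimethylmorpholin-4-yl in place of piperidin-1-yl on a carbonyl carbon. In words, 2,6-dimethylmorpholin-4-yl stands in place of piperidin-1-yl on a carbonyl carbon. For the measured compounds named here, no measured pair shows this exchange on its own, so the expectation rests on little. With compound 2 at 42200 nM as the anchor, no change beyond the usual scatter is expected in this assay, in either direction. The expected change is a 1.1-fold higher number from compound 2 to compound 3 (0.03 log units; within the scatter). The result may well arrive only as a limit. For compound 3 the estimated value is 45000 nM, with an expected range from 22000 nM to 80000 nM.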

Compound 3, half-maximal inhibitory concentration: > 50000 nM
Compound 3: no number, only a limit; the forecaster's own chance of this, stated with the estimate: 55%; middle value at least 1.1-fold (0.04 log units) away from the limit.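

Among the compounds shown here, replacing piperidin-1-yl with 2,6-dimethylmorpholin-4-yl on a carbonyl carbon gives the first readable single change in this assay: an at least 1.1-fold higher number from compound 2 to compound 3 (0.07 log units; that floor lies within the scatter). Compound 3 reads only as a limit, so this step has a floor but no measured size, and the real change could be small or much larger; what it does show is that this exchange gives no sign of stronger inhibition on these cells. The other step, methyl in place of hydrogen on a saturated chain carbon bound to an aromatic nitrogen and a saturated chain carbon, cannot be read, and the series offers little room for such comparisons at the weak end of the range: the limit of > 50000 nM in this assay, at which 2 of the 3 values shown sit.

On these data alone, it remains open which part of the exchange matters, the ring oxygen or the two methyl groups, and a plain morpholin-4-yl on the same carbonyl carbon would separate the two. Also open, as far as these compounds go, is whether a different group there, such as a piperazin-1-yl with its free amine, could give a clearly lower number than compound 2 at 42200 nM.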